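Hydroxyphenyl position and five-membered ring in the series

The compounds below may be only part of what the source reports. "The series", "measured", "known", "first", "only" and "open" are said of these compounds alone.

Compound 1 `Oc1cccc(-c2cc(-c3cccs3)cc(-c3cccc(O)c3)n2)c1` gives 1690 nM in a functional assay on HeLa cells (Homo sapiens) for cytotoxicity, read by CCK-8 assay; a lower number here means a stronger inhibitor, a higher number a weaker inhibitor. Compound 2 `Oc1ccc(-c2cc(-c3cccs3)cc(-c3cccc(O)c3)n2)cc1` carries 4-hydroxyphenyl in place of 3-hydroxyphenyl on an aromatic carbon and gives 4140 nM in this assay, a step of a 2.4-fold higher number from compound 1 to compound 2 (0.39 log units; beyond the scatter). Compound 3 `Oc1cccc(-c2cc(-c3ccco3)cc(-c3cccc(O)c3)n2)c1` gives 5990 nM in this assay, a step of a 3.5-fold higher number from compound 1 to compound 3 (0.55 log units; beyond the scatter). Compound 4 `Oc1ccc(-c2cc(-c3ccco3)cc(-c3cccc(O)c3)n2)cc1` is not yet measured; it differs from compound 3 by 4-hydroxyphenyl in place of 3-hydroxyphenyl on an aromatic carbon. This is the same kind of change as that made in compound 2, but the two cores differ by furan-2-yl in place of thiophen-2-yl on an aromatic carbon, so the place is meta to a furan-2-yl group here rather than meta to a thiophen-2-yl group. Within the data shown here, a step of about a 2.2-fold higher number from compound 3 to compound 4 (0.34 log units; beyond the scatter) is expected from compound 3 to compound 4 in this assay, because a 2.4-fold higher number from compound 1 to compound 2 (0.39 log units; beyond the scatter) is the only precedent for this change. Compound 4 is therefore estimated at 13000 nM, expected between 6000 nM and 30000 nM.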

Compound 4, half-maximal inhibitory concentration: 5170 nM
Estimate against measurement, compound 4: 2.5-fold (0.40 log units) above; the whole stated range lies above it.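

In this assay, 4-hydroxyphenyl in place of 3-hydroxyphenyl gives a 1.2-fold lower number from compound 3 to compound 4 (0.06 log units; within the scatter) on the core carrying furan-2-yl, which does not repeat the step seen on the core carrying thiophen-2-yl: the same change on two cores in this assay, a 2.4-fold higher number (0.39 log units; beyond the scatter) from compound 1 to compound 2 and a 1.2-fold lower number (0.06 log units; within the scatter) from compound 3 to compound 4, 2.8-fold (0.45 log units) apart, beyond the scatter of two such steps. Furan-2-yl in place of thiophen-2-yl gives a 1.2-fold higher number from compound 2 to compound 4 (0.10 log units; within the scatter) when 4-hydroxyphenyl is present, and this too departs from the earlier step: the same change on two cores in this assay, a 3.5-fold higher number (0.55 log units; beyond the scatter) from compound 1 to compound 3 and a 1.2-fold higher number (0.10 log units; within the scatter) from compound 2 to compound 4, 2.8-fold (0.45 log units) apart, beyond the scatter of two such steps. Neither change therefore carries over as a fixed step in these four compounds, though a single set of four cannot show why, or whether this holds elsewhere in the series.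

Still open, going by these compounds, is whether the same dependence appears with an amine or a methoxy group in place of the hydroxyl. Also open, on these data alone, is how a pyrrole or a plain phenyl ring would compare with furan-2-yl and thiophen-2-yl.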